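This account rests on a few compounds, and the source may have more. Where it says the series, first, only, none or still open, it means among the compounds named here.

Measured compounds:
compound 1, `CCOC(=O)[C@@H]1CCCN(S(=O)(=O)c2ccc(S(=O)(=O)N(CC)C(C)C)cc2)C1`, 1000 nM
compound 2, `CCN(CC)S(=O)(=O)c1ccc(S(=O)(=O)N2CCC[C@@H](C(=O)NC3CN(S(C)(=O)=O)C3)C2)cc1`, 2500 nM

In a functional assay on MIA PaCa-2 cells (Homo sapiens) for inhibition, read by MTT assay, with a stated time of 7 days (on this read-out lower numbers stand for stronger inhibition and higher numbers for weaker inhibition), compound 1 gives the lowest of the two numbers; compound 2 gives 2500 nM, a higher number lying beyond the usual scatter. Compound 3, `CCOC(=O)[C@@H]1CCCN(S(=O)(=O)c2ccc(S(=O)(=O)N(C)C)cc2)C1`, has not yet been tested. It differs from compound 1 in one place: dimethylamino in place of ethyl(isopropyl)amino on a sulfonyl sulfur. Going by the values given here, no measured pair shows the effect of such a change, so the expected step of a 1.5-fold higher number from compound 1 to compound 3 (0.18 log units; within the scatter) is small and within the scatter, if anything toward a weaker number. Compound 3 is therefore estimated at 1500 nM, expected between 500 nM and 5000 nM.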

Compound 3, half-maximal inhibitory concentration: 900 nM
Estimate against measurement, compound 3: 1.7-fold (0.22 log units) above; the measured number falls inside the stated range.
By their numbers in this assay, from the lowest: compounds 3 and 1 (each within the scatter of the next); then compound 2.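

Going by these compounds alone, compound 1 and compound 3 form the first pair to isolate this position: in this assay, dimethylamino in place of ethyl(isopropyl)amino on a sulfonyl sulfur gives a 1.1-fold lower number from compound 1 to compound 3 (0.05 log units; within the scatter). The read-out therefore does not separate these two amines, and the larger ethyl(isopropyl)amino group is not needed to keep the number on this core. Nothing available explains this result.

On these data alone, it remains open whether morpholine, dibutylamino or an unsubstituted amino group on the same sulfur would also leave the number unchanged. As far as these compounds go, it is equally open whether any group there could move the number beyond the scatter.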